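The compounds below may be only part of what the source reports. "The series", "measured", "known", "first", "only" and "open" are said of these compounds alone.

Of the compounds shown here, three sharing one core have been measured in a functional assay on PC-3 cells (Homo sapiens) for antiproliferative activity, read by MTT assay, with a stated time of 72 h; on this read-out higher numbers stand for weaker inhibition and lower numbers for stronger inhibition. Compound 1 `O=S(=O)(c1ccc(-c2cnc(C3CC3)o2)cc1)N1CCSc2ccccc21` gives 49 nM. Compound 2 `Nc1ccc2c(c1)OCCCN2S(=O)(=O)c1ccc(-c2cnc(C3CC3)o2)cc1` gives 33 nM. Compound 3 `O=S(=O)(c1ccc(-c2cnc(C3CC3)o2)cc1)N1CCCOc2ccccc21` gives 27 nM, the lowest of the three numbers, yet both gaps are small: compound 2 lies within the scatter of compound 3, and so does compound 1. Among the measured compounds shown here, the only single-place step among them, a 1.2-fold lower number from compound 2 to compound 3 (0.09 log units; within the scatter), removes an amino group from an aromatic carbon and leaves the read-out essentially unchanged.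

Compound 4 `O=S(=O)(c1ccc(-c2cnc(C3CC3)o2)cc1)N1CCCOc2ccc(F)cc21` is the next structure in this assay. Compared with compound 3 it carries fluoro in place of hydrogen on an aromatic carbon. For the measured compounds named here, no measured step exchanges hydrogen for fluoro, so the only guidance comes from the step from compound 2 to compound 3, where a change on the same aromatic ring stayed within the scatter. A single fluorine added at an aromatic carbon is a small change, and nothing in the data points one way or the other, so for compound 4 the expected step is a 1.1-fold higher number from compound 3 to compound 4 (0.05 log units; within the scatter), none beyond the scatter. Compound 4 is therefore estimated at 30 nM, with a likely range from 12 nM to 75 nM.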

Compound 4, half-maximal inhibitory concentration: 18 nM
Compound 4: middle estimate off by 1.7-fold (0.22 log units), on the high side; the range from low to high includes it.
By their numbers in this assay, from the lowest: compounds 4, 3, 2 and 1 (each within the scatter of the next, the first and the last beyond it).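

Among the compounds shown here, the step of a 1.5-fold lower number from compound 3 to compound 4 (0.18 log units; within the scatter) is the first view of a fluoro group on this aromatic carbon, meta to a fused ring and para to a fused ring, in this assay. Swapping hydrogen for this single fluorine atom therefore leaves the read-out in the same range, and the assay cannot separate the two compounds, so this carbon accepts a fluoro group with no measurable loss of antiproliferative activity. No measurement is available that would explain this result.

The compounds shown leave open whether this tolerance holds only for a group as small as fluoro or extends to larger groups on the same carbon, such as chloro, methoxy or trifluoromethyl, and whether a charged group such as a carboxylic acid would be accepted there too. For the compounds shown here, with hydrogen and fluoro as the only two groups compared at this carbon, they also cannot show whether any group placed here would move the number by more than the usual scatter of repeated measurements, in either direction.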